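A few compounds are considered here, and "the series" means these few. Any claim that something is new, unique, unknown or untested is made for them only; others in the source may bear on it.

Series notes. The set holds compound 1 `Clc1ccc(-c2noc(Cn3ccnc3)n2)cc1`, compound 2 `Cc1cccc(-c2noc(Cn3cncn3)n2)c1` and the not yet measured compound 3 `Fc1cccc(-c2noc(Cn3cncn3)n2)c1`. The read-out is a toxicity assay on the whole organism (strain Wistar) with Rattus norvegicus as the target, with a stated time of 1 h; on this read-out lower numbers stand for an effect already at smaller amounts and higher numbers for an effect only at larger amounts of compound. In this assay compound 1 gives > 500 mg/kg, which is a limit of the assay and not a number. In this assay compound 2 gives 219 mg/kg. Compound 2 therefore stands as the only numerical result shown so far. The other value shown, that of compound 1, is a limit, matching (the limit of > 500 mg/kg in this assay, at which 1 of the 2 values shown sits). Among the measured compounds shown here, no step between two measured compounds is recorded; one of the two values is a limit.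

Compound 3 differs from compound 2 by fluoro in place of methyl on an aromatic carbon. For the measured compounds named here, with no measured step to lean on, the expected change in this assay is a 1.1-fold higher number from compound 2 to compound 3 (0.06 log units; within the scatter), taken as a small one with no clear direction beyond the usual scatter. For compound 3 the estimate in this assay is 250 mg/kg, with an expected range from 120 mg/kg to 500 mg/kg.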

Compound 3, dose for half-maximal effect: 128 mg/kg
Compound 3: the middle estimate sits 2.0-fold (0.29 log units) above what was measured; measured number inside the range.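

In this assay the series now has its first readable step, at a place on an aromatic carbon of a six-membered aromatic ring of carbon only, meta to a large group: exchanging methyl for fluoro gives a 1.7-fold lower number from compound 2 to compound 3 (0.23 log units; within the scatter). Among the compounds shown here, both compounds give numbers rather than limits, so this position accepts fluoro in place of methyl without a shift that stands clear of the usual scatter of this read-out, and the single step supports no claim of a trend. Nothing on hand bears on why the two compounds sit where they do.

For the compounds shown here, compound 1 stands at a limit of the assay rather than a number and differs from the others in more than one place, so no step to it can be read. Still open, as far as these compounds go, is whether a group of another kind at this same place, such as an amine, a carboxylic acid or a longer chain, would move the number in this assay beyond the scatter.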